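Series notes: aryl exchange from compound 1 to compound 4

The source may report more compounds than this note shows. Statements on the series, on what has been measured and on what is new or still open speak of the compounds shown alone.

Measured compounds:
- compound 1, `CCOC(=O)c1cnn(-c2nc(-c3ccccc3F)c(C#N)c(=O)n2C)c1N`, gives 87 ug/mL in a functional assay, with a stated time of 150 min; a lower number here means a stronger inhibitor, a higher number a weaker inhibitor
- compound 2, `COc1cccc(-c2nc(SC)n(C)c(=O)c2C#N)c1OC`, gives 67 ug/mL in this assay
- compound 3, `Cn1c(NN)nc(-c2ccc(Cl)cc2)c(C#N)c1=O`, gives 59 ug/mL in this assay

Compound 1 stands at the highest of the three numbers, yet its gap to compound 2 and its gap to compound 3 both lie within the usual scatter, so the three measured compounds are not separated from one another on these numbers.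

Compound 4, `CCOC(=O)c1cnn(-c2nc(-c3ccc(Cl)cc3)c(C#N)c(=O)n2C)c1N`, has not yet been measured. It differs from compound 1 in one place: 4-chlorophenyl in place of 2-fluorophenyl on an aromatic carbon. Within the data shown here, no pair of measured compounds shows this change on its own; compound 3 also carries a 4-chlorophenyl, but it differs from compound 1 in further places, so its value says nothing about this change in isolation. Among the measured compounds shown here, with no such step available, the expectation is for no change beyond the scatter, in either direction. Compound 4 is expected to give about 72 ug/mL, with a range of 36 ug/mL to 145 ug/mL. The step this estimate implies, a 1.2-fold lower number from compound 1 to compound 4 (0.08 log units; within the scatter), is expected to remain within the scatter.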

Compound 4, half-maximal inhibitory concentration: 87 ug/mL
Compound 4: middle estimate off by 1.2-fold (0.08 log units), on the low side; the measured number falls inside the stated range.
By their numbers in this assay, from the lowest: compounds 3, 2, 1 and 4 (each within the scatter of the next).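

Among these compounds, the exchange of 2-fluorophenyl for 4-chlorophenyl on the aromatic carbon ortho to a cyano group gives the first single-place reading at this position: in this assay it produces no change at the digits printed from compound 1 to compound 4 (within the scatter). On the core of compound 1, this position therefore carries either aryl group without a shift beyond the scatter, although the halogen and its place on the phenyl ring change together, so this single step cannot separate the two. Nothing measured here explains the flat step.

Still open, as far as these compounds go, is whether the flat reading extends to groups of another kind at this position, such as a cyclohexyl, an aminophenyl or a phenyl bearing a carboxylic acid. The fluorine and chlorine placements also remain to be read one at a time, for example with 4-fluorophenyl or 2-chlorophenyl.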